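The source may hold more compounds than are shown below. What is called first, only, known or untested is meant among the compounds shown, and "the series" means these compounds.

Compound 1, `CCCc1ccc(C#CC#Cc2cn([C@H]3C[C@H](O)[C@@H](CO)O3)c(=O)[nH]c2=O)cc1`, compound 2, `Nc1cccc(C#CC#Cc2cn([C@H]3C[C@H](O)[C@@H](CO)O3)c(=O)[nH]c2=O)c1`, and compound 3, `O=c1[nH]c(=O)n([C@H]2C[C@H](O)[C@@H](CO)O2)cc1C#CC#Cc1ccc([N+](=O)[O-])cc1`, share one core and differ only in the aryl group on the terminal triple-bonded carbon. In an ADME assay on HEL cells (Homo sapiens), read by cell counting, with a stated time of 3 days (on this read-out lower numbers stand for higher toxicity in this test and higher numbers for lower toxicity in this test), compound 1 gives 52000 nM. Compound 3 gives 89000 nM, so that a 1.7-fold higher number from compound 1 to compound 3 (0.23 log units; within the scatter). For compound 2 this assay reports only a limit, > 100000 nM, and compound 2 therefore stands at the limit of > 100000 nM in this assay, at which 1 of the 3 values shown sits, the highest position among the three values. The steps into and out of compound 2 are both bounded: an at least 1.9-fold higher number from compound 1 to compound 2 (0.28 log units; that floor lies within the scatter), and an at least 1.1-fold lower number from compound 2 to compound 3 (0.05 log units; that floor lies within the scatter). Compound 4, `O=c1[nH]c(=O)n([C@H]2C[C@H](O)[C@@H](CO)O2)cc1C#CC#CC1CC1`, is not yet measured; it follows from compound 2 through (cyclopropyl in place of 3-aminophenyl on a triple-bonded carbon). The two measured exchanges of the group on that triple-bonded carbon both stayed within the scatter, so no step beyond the scatter is expected here either, and the number for compound 4 is expected to stay near the limit, as an at least 1.1-fold lower number from compound 2 to compound 4 (0.04 log units; that floor lies within the scatter). Compound 4 is accordingly estimated at 90000 nM, with a range from 40000 nM to 200000 nM.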

Compound 4, half-maximal cytotoxic concentration: > 100000 nM
Compound 4: a limit, no number (the forecaster's own chance of this, stated with the estimate: 45%); at least 1.1-fold (0.04 log units) between middle value and limit.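

In this assay, the aromatic ring at this position turns out not to be needed for the read-out to reach the limit, since the small non-aromatic cyclopropyl on the triple-bonded carbon ends at the same limit as 3-aminophenyl: the limit of > 100000 nM in this assay, at which 2 of the 4 values shown sit. The step between compound 2 and compound 4 cannot be read, as both values are limits and not numbers. The two readable steps, an at least 1.1-fold higher number from compound 3 to compound 4 (0.05 log units; that floor lies within the scatter) and an at least 1.9-fold higher number from compound 1 to compound 4 (0.28 log units; that floor lies within the scatter), have floors that stay within the scatter, so even this exchange of an aryl group for cyclopropyl shows no change that can be told from scatter.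

The compounds shown leave open where compound 2 and compound 4 truly lie past the limit. They also leave open whether a longer alkyl chain or a carboxylic acid on the same triple-bonded carbon would move the number beyond the scatter.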